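This account rests on a few compounds, and the source may have more. Where it says the series, first, only, none or still open, it means among the compounds named here.

Measured so far:
compound 1 `CC(C)(C)c1ccc(C(=O)Nc2cccc(NC(=O)COc3ccc4c(=O)ccoc4c3)c2)cc1` — 165 nM
compound 2 `N#Cc1ccc(C(=O)Nc2cccc(NC(=O)COc3ccc4c(=O)ccoc4c3)c2)cc1` — 123 nM

Among the measured compounds shown here, in an assay on isolated protein for inhibition of Rho-associated protein kinase 1 (Homo sapiens), read by scintillation counting, radiometric assay and 33P incorporation, with a stated time of 40 min, in the presence of a further agent that is not named here (a lower number here means a stronger inhibitor, a higher number a weaker inhibitor), compound 2 and compound 1 are not separated beyond the scatter; the single measured step, a 1.3-fold lower number from compound 1 to compound 2 (0.13 log units; within the scatter), changes only the group on that aromatic carbon. Compound 3 `COc1ccc(C(=O)Nc2cccc(NC(=O)COc3ccc4c(=O)ccoc4c3)c2)cc1` differs from compound 2 by methoxy in place of cyano on an aromatic carbon. For the measured compounds named here, only that one step bears on this place, and it was within the scatter, so no step beyond the scatter is expected here either: the expected change is a 1.2-fold higher number from compound 2 to compound 3 (0.09 log units; within the scatter). Compound 3 is therefore estimated at 150 nM in this assay, with a range from 60 nM to 400 nM.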

Compound 3, half-maximal inhibitory concentration: 18 nM
Compound 3: middle estimate off by 8.3-fold (0.92 log units), on the high side; the whole stated range lies above it.
By their numbers in this assay, from the lowest: compound 3; then compounds 2 and 1 (each within the scatter of the next).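

In this assay, the group on this aromatic carbon, para to a large group, can clearly move the number: a 6.8-fold lower number from compound 2 to compound 3 (0.83 log units; beyond the scatter) and a 9.2-fold lower number from compound 1 to compound 3 (0.96 log units; beyond the scatter), although the earlier cyano and tert-butyl pair stayed within the scatter. Cyano and methoxy have the same heavy-atom count and hydrogen-bond acceptor count, yet compound 3 is the strongest of the three. No measurement here accounts for this difference.

Open, from the compounds shown here alone, is whether ethoxy, hydroxyl or dimethylamino on this carbon would keep the number of compound 3.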